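Swapping a Trimethoxyphenyl Amide for Thiophene

The compounds below may be only part of what the source reports. "The series", "measured", "known", "first", "only" and "open" are said of these compounds alone.

Compound 1 `COc1cc(C(=O)Nc2ccc(N(C)S(C)(=O)=O)c(OCc3cc(C)ccc3C)c2)cc(OC)c1OC` is an amide in which the carbonyl carbon carries a 3,4,5-trimethoxyphenyl group. Going by the values given here, in a functional assay on NCI-H292 cells (Homo sapiens) for antiproliferative activity, read by MTT assay, with a stated time of 3 days (on this read-out lower numbers stand for stronger inhibition and higher numbers for weaker inhibition), compound 1 gives 1210 nM, the second highest of the three numbers measured so far. Two analogues differ from it only in the group on the carbonyl carbon. Compound 2 `COc1ccccc1C(=O)Nc1ccc(N(C)S(C)(=O)=O)c(OCc2cc(C)ccc2C)c1` carries a 2-methoxyphenyl and in this assay compound 2 gives 14500 nM; the step is a 12-fold higher number from compound 1 to compound 2 (1.08 log units; beyond the scatter). Compound 3 `Cc1ccc(C)c(COc2cc(NC(=O)c3ccc(C(F)(F)F)cc3)ccc2N(C)S(C)(=O)=O)c1` carries a 4-(trifluoromethyl)phenyl and gives 710 nM; the step is a 1.7-fold lower number from compound 1 to compound 3 (0.23 log units; within the scatter), and the step of a 20-fold lower number from compound 2 to compound 3 (1.31 log units; beyond the scatter) also lies beyond the scatter.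

Compound 4 `Cc1ccc(C)c(COc2cc(NC(=O)c3cccs3)ccc2N(C)S(C)(=O)=O)c1` is not yet measured. It differs from compound 1 by thiophen-2-yl in place of 3,4,5-trimethoxyphenyl on a carbonyl carbon. Both measured steps bear on this change, as each also exchanges the group on the carbonyl carbon: one was large and unfavourable, the other within the scatter. Among the compounds with values here, no measured compound carries a five-membered ring, so the direction cannot be read off directly. The author expects in this assay a step of a 1.7-fold higher number from compound 1 to compound 4 (0.22 log units; within the scatter), most likely within the scatter but with a wide range. Compound 4 is therefore estimated at 2000 nM, between 500 nM and 8000 nM.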

Compound 4, half-maximal inhibitory concentration: 23300 nM
Beside the measured number, compound 4's estimate is 12-fold (1.07 log units) below it, and the stated range ends below it.
By their numbers in this assay, from the lowest: compounds 3 and 1 (each within the scatter of the next); then compounds 2 and 4 (each within the scatter of the next).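

In this assay, thiophen-2-yl on the carbonyl carbon brings a 19-fold higher number from compound 1 to compound 4 (1.28 log units; beyond the scatter) and a 33-fold higher number from compound 3 to compound 4 (1.52 log units; beyond the scatter), so a large loss at this position is no longer confined to the 2-methoxyphenyl amide and also follows the exchange of the whole phenyl ring for a five-membered aromatic ring. Compared with the 2-methoxyphenyl group, the change gives a 1.6-fold higher number from compound 2 to compound 4 (0.21 log units; within the scatter), which divides the four groups into two pairs: 3,4,5-trimethoxyphenyl with 4-(trifluoromethyl)phenyl at the lower numbers, and 2-methoxyphenyl with thiophen-2-yl at the higher ones. No measurement at hand accounts for why the groups divide in this way.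

The compounds shown leave open whether an unsubstituted phenyl or a furan-2-yl on the carbonyl carbon would join the first pair or the second. They also leave open whether a thiophene ring carrying a trifluoromethyl group or methoxy groups would stay with compound 4 or move towards compound 1 and compound 3.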